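The compounds below may be only part of what the source reports. "The series", "measured", "known", "first", "only" and "open" are said of these compounds alone.

Three compounds have been measured in a functional assay on HL-60 cells (Homo sapiens) for cytotoxicity, read by MTT assay, with a stated time of 24 h; a higher number here means a weaker inhibitor, a lower number a stronger inhibitor:

compound 1 `Brc1ccc(Oc2cc(Br)cc(Br)c2OCCCCCN2CCN(C/C=C/c3ccccc3)CC2)c(Br)c1` gives 47.2 ug/mL;
compound 2 `Brc1ccc(Oc2cc(Br)cc(Br)c2OCc2ccccc2)c(Br)c1` gives 27.9 ug/mL;
compound 3 `CCOC(=O)C(C)Oc1c(Br)cc(Br)cc1Oc1ccc(Br)cc1Br` gives 35.7 ug/mL.

Compound 2 has the lowest of the three numbers, but its neighbours are close: compound 3 lies within the scatter of it, and compound 1, the furthest away, also lies within the scatter, so no order among the three can be claimed. The step of interest leads from compound 2 to compound 4 `CC(=O)Oc1c(Br)cc(Br)cc1Oc1ccc(Br)cc1Br`, which has not yet been measured. The change is acetyl in place of benzyl on an oxygen on an aromatic ring. Going by the values given here, one measured step bears on it: the step of a 1.3-fold higher number from compound 2 to compound 3 (0.11 log units; within the scatter), in which the benzyl on the same oxygen was also replaced by a group without a ring, and the number did not move beyond the scatter. On that basis the exchange of benzyl for acetyl is expected to leave the number of compound 4 close to that of compound 2, with at most a small drift upward, a step of about a 1.2-fold higher number from compound 2 to compound 4 (0.09 log units; within the scatter) that is estimated to stay within the scatter. Compound 4 is therefore expected to give about 34 ug/mL in this assay, within a range from 18 ug/mL to 65 ug/mL.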

Compound 4, half-maximal inhibitory concentration: 29.9 ug/mL
For compound 4 the middle estimate is 1.1-fold (0.06 log units) above the measured one, and the stated range covers the measured number.
By their numbers in this assay, from the lowest: compounds 2, 4, 3 and 1 (each within the scatter of the next).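

In this assay, the exchange on an oxygen on an aromatic ring gives a 1.1-fold higher number from compound 2 to compound 4 (0.03 log units; within the scatter), so acetyl, with 3 heavy atoms and no ring, cannot be told apart from benzyl, with 7 heavy atoms and a six-membered aromatic ring. The second exchange at this oxygen gives a 1.2-fold lower number from compound 3 to compound 4 (0.08 log units; within the scatter), so acetyl and 1-(ethoxycarbonyl)ethyl cannot be told apart either. Benzyl, acetyl and 1-(ethoxycarbonyl)ethyl thus form a set of three groups at this position that the assay does not separate, which a single step could not show.

Nothing available gives a reason for this lack of separation. The compounds shown leave open whether a bare hydroxyl or a carboxylic acid at this position would move the number beyond the scatter.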